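Chain-length swap on the amide of an aryl sulfonate

A few compounds are considered here, and "the series" means these few. Any claim that something is new, unique, unknown or untested is made for them only; others in the source may bear on it.

Measured compounds:
- compound 1, `CC(C)C(=O)Nc1ccc(S(=O)(=O)Oc2ccccc2C(C)C)cc1`, 14000 nM
- compound 2, `CC(C)C(=O)Nc1ccc(S(=O)(=O)Oc2ccccc2I)cc1`, 13000 nM
- compound 3, `CC(C)c1ccccc1OS(=O)(=O)c1ccc(NC(=O)CCCl)cc1`, 16000 nM

Of the compounds shown here, three have been tested in a functional assay on HT-29 cells (Homo sapiens) for antiproliferative activity, read by sulforhodamine B assay, with a stated time of 48 h; a higher number here means a weaker inhibitor, a lower number a stronger inhibitor. Compound 1 gives 14000 nM, compound 2 gives 13000 nM, and compound 3 gives 16000 nM. Compound 2 stands within the usual scatter of both neighbours: a 1.1-fold lower number from compound 1 to compound 2 (0.03 log units; within the scatter), and the gap to compound 3 is also within scatter, so none of the three can be told apart.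

Compound 4, `O=C(CCCCl)Nc1ccc(S(=O)(=O)Oc2ccccc2I)cc1`, has not yet been measured. It differs from compound 2 in one place: 3-chloropropyl in place of isopropyl on a carbonyl carbon. The measured step that bears most directly on this is a 1.1-fold higher number from compound 1 to compound 3 (0.06 log units; within the scatter), a closely related swap at the same carbonyl carbon that produced no shift beyond the scatter. Given that, no step beyond the scatter is expected in this assay; the expected step is a 1.1-fold higher number from compound 2 to compound 4 (0.03 log units; within the scatter). Compound 4 is therefore estimated at 14000 nM, with a range from 7000 nM to 30000 nM.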

Compound 4, half-maximal inhibitory concentration: 9100 nM
For compound 4 the middle estimate is 1.5-fold (0.19 log units) above the measured one, within the range that was stated.
By their numbers in this assay, from the lowest: compounds 4, 2, 1 and 3 (each within the scatter of the next).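

In this assay, putting 3-chloropropyl in place of isopropyl on the carbonyl carbon gives a 1.4-fold lower number from compound 2 to compound 4 (0.15 log units; within the scatter) and so leaves the compounds indistinguishable. The earlier swap at this carbonyl carbon was read only with isopropyl on the aromatic ring, whereas this one is read with iodo there, so the position has now taken two chlorine-bearing chains, under two different partners, without a shift beyond the scatter. Nothing among the data shown offers an explanation for this tolerance.

Still open, on these data alone, is whether this carbonyl carbon would respond to a group of a different kind, such as an amine or a carboxylic acid. A plain propyl chain at the same place would also help to separate any contribution of the chlorine from that of the chain.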